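Adding a morpholinylcarbonyl group to a dichlorophenyl pyridine

A few compounds are considered here, and "the series" means these few. Any claim that something is new, unique, unknown or untested is made for them only; others in the source may bear on it.

Compound 1 `Clc1cccc(-c2ccc(N3CCCCCC3)nc2)c1Cl` gives 30 mL.min-1.g-1 in an in vitro ADME assay on microsomes from liver (Rattus norvegicus) for pharmacokinetics (a lower number here means slower removal, a higher number faster removal of the compound), and stands highest of the two numbers recorded. Its nearest neighbour is compound 2 `C[C@@H]1CC[C@H](C)N1c1ccc(-c2cccc(Cl)c2Cl)cn1`, which in this assay gives 11 mL.min-1.g-1; the step of a 2.7-fold lower number from compound 1 to compound 2 (0.44 log units; beyond the scatter) is the only one measured. Compound 3 `O=C(c1cc(-c2cccc(Cl)c2Cl)cnc1N1CCCCCC1)N1CCOCC1` differs from compound 1 by (morpholin-4-yl)carbonyl in place of hydrogen on an aromatic carbon, on an aromatic carbon of a six-membered aromatic ring with 1 nitrogen, ortho to an azepan-1-yl group, two atoms from the ring nitrogen and meta to a 2,3-dichlorophenyl group. Going by the values given here, the one measured step concerns an exchange of the saturated ring on the other side of the shared core, not an added carbonyl group, so it bears only loosely on the present change. No closer comparison exists, so for compound 3 the step of a 1.3-fold lower number from compound 1 to compound 3 (0.10 log units; within the scatter) is expected to stay within the usual scatter. Compound 3 is therefore estimated at 24 mL.min-1.g-1, with a range from 8 mL.min-1.g-1 to 65 mL.min-1.g-1.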

Compound 3, intrinsic clearance in microsomes: > 50 mL.min-1.g-1
Compound 3 was reported as a limit; the forecaster's own chance of this, stated with the estimate: 5%; middle value at least 2.0-fold (0.31 log units) away from the limit.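

For compound 3 the reading in this assay is a limit and not a number: the limit of > 50 mL.min-1.g-1 in this assay, at which 1 of the 3 values shown sits. Putting (morpholin-4-yl)carbonyl in place of hydrogen on this aromatic carbon, ortho to an azepan-1-yl group and two atoms from the ring nitrogen, gives an at least 1.6-fold higher number from compound 1 to compound 3 (0.22 log units; that floor lies within the scatter). This addition therefore shows no sign of slower removal, whereas the exchange of azepan-1-yl for 2,5-dimethylpyrrolidin-1-yl does: a 2.7-fold lower number from compound 1 to compound 2 (0.44 log units; beyond the scatter).

The compounds shown leave open how far past the limit compound 3 lies, and so whether its true step goes beyond the scatter. They also leave open how a carboxylic acid or an amine would read at this same aromatic carbon, and whether (morpholin-4-yl)carbonyl would read the same with 2,5-dimethylpyrrolidin-1-yl in place of azepan-1-yl.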